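Arylthiadiazole selenium heterocycles: antiproliferative activity on SSMC-7721 cells

This account rests on a few compounds, and the source may have more. Where it says the series, first, only, none or still open, it means among the compounds named here.

Measured compounds:
compound 1, `O=c1c2ccccc2[se]n1-c1nnc(-c2ccc(Cl)cc2)s1`, 24400 nM
compound 2, `O=c1c2ccccc2[se]n1-c1nnc(-c2ccccc2Cl)s1`, 40200 nM

Two compounds share a common core and differ only in the aryl group on the five-membered ring. In a functional assay on SSMC-7721 cells (Homo sapiens) for antiproliferative activity, read by CCK-8 assay, with a stated time of 48 h (on this read-out higher numbers stand for weaker inhibition and lower numbers for stronger inhibition), compound 1 gives 24400 nM, and compound 2 gives 40200 nM. For the measured compounds named here, the one measured step, a 1.6-fold higher number from compound 1 to compound 2 (0.22 log units; within the scatter), is within the scatter, so the two compounds cannot be ordered against each other; compound 2 merely carries the higher of the two numbers.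

Compound 3, `Cc1cccc(-c2nnc(-n3[se]c4ccccc4c3=O)s2)c1`, is not yet measured. It differs from compound 2 by 3-methylphenyl in place of 2-chlorophenyl on an aromatic carbon. Going by the values given here, no measured step covers an exchange of chlorine for methyl or a move of the substituent around the phenyl ring; the only step at hand, from compound 1 to compound 2, changed the position of chlorine and stayed within the scatter. Compound 3 is therefore expected to show no step beyond the scatter, a 1.3-fold lower number from compound 2 to compound 3 (0.10 log units; within the scatter). The estimate for compound 3 is 32000 nM, in the range 11000 nM to 95000 nM.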

Compound 3, half-maximal inhibitory concentration: 17800 nM
Compound 3: middle estimate off by 1.8-fold (0.25 log units), on the high side, within the range that was stated.
By their numbers in this assay, from the lowest: compounds 3, 1 and 2 (each within the scatter of the next, the first and the last beyond it).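

In this assay, for the compounds shown here, the exchange of 2-chlorophenyl for 3-methylphenyl on the aromatic carbon gives a modest step, a 2.3-fold lower number from compound 2 to compound 3 (0.35 log units; beyond the scatter), and this is the first step at this position to lie beyond the scatter. Against 4-chlorophenyl the same group gives a 1.4-fold lower number from compound 1 to compound 3 (0.14 log units; within the scatter), which is within the scatter, so compound 3 and compound 1 cannot be ordered against each other, and the aryl exchanges at this position have so far moved the number only slightly. No supporting data bear on why compound 3 and compound 2 differ.

On these data alone, the step from 2-chlorophenyl to 3-methylphenyl changes the substituent and its place on the phenyl ring together, so what each contributes remains open. As far as these compounds go, how a methoxy group, an amine or a carboxylic acid on the phenyl ring would read in this assay also remains open.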